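Piperidinyl amide on the isoxazole analogue of the series

A few compounds are considered here, and "the series" means these few. Any claim that something is new, unique, unknown or untested is made for them only; others in the source may bear on it.

Two members of the series have been run in a functional assay on LoVo cells (Homo sapiens) for antiproliferative activity, read by MTT assay, with a stated time of 72 h; on this read-out higher numbers stand for weaker inhibition and lower numbers for stronger inhibition. Compound 1 `Cn1cc(-c2nn(Cc3ccc(C(=O)N4CCCCC4)cc3)c(=O)c3ccccc23)cn1` gives 77100 nM in this assay. Compound 2 `Cc1noc(C)c1-c1nn(Cc2ccc(C(=O)NC3CC3)cc2)c(=O)c2ccccc12` returns only > 100000 nM in this assay, which is a limit of the assay and not a number, so compound 2 stands at the upper edge of what the read-out reports (the limit of > 100000 nM in this assay, at which 1 of the 2 values shown sits). Compound 3 `Cc1noc(C)c1-c1nn(Cc2ccc(C(=O)N3CCCCC3)cc2)c(=O)c2ccccc12` has not been measured. It differs from compound 2 by piperidin-1-yl in place of cyclopropylamino on a carbonyl carbon. Compound 1 carries the same (piperidin-1-yl)carbonyl group and gives 77100 nM in this assay, so compound 3 is expected to land in the same weak region, with the step from an at least 1.1-fold lower number from compound 2 to compound 3 (0.04 log units; that floor lies within the scatter) judged as small, if any, and most likely within the scatter. Compound 3 is therefore estimated at 90000 nM in this assay, within a range of 30000 nM to 300000 nM.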

Compound 3, half-maximal inhibitory concentration: > 100000 nM
Compound 3 gave a limit, no number; the forecaster's own chance of this, stated with the estimate: 45%; middle value at least 1.1-fold (0.04 log units) away from the limit.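

In this assay compound 3 also gives only a limit of the assay, not a number: the limit of > 100000 nM in this assay, at which 2 of the 3 values shown sit. The step between compound 2 and compound 3 cannot be read, so the exchange of cyclopropylamino for piperidin-1-yl on the carbonyl carbon has no measurable size here. With the (piperidin-1-yl)carbonyl group held constant, 3,5-dimethyl-1,2-oxazol-4-yl in place of 1-methyl-1H-pyrazol-4-yl on an aromatic carbon gives an at least 1.2-fold higher number from compound 1 to compound 3 (0.11 log units; that floor lies within the scatter), so this pair does not establish a real difference between the two groups.

Going by these compounds, whether a morpholin-4-yl group or a hydroxyl group, which would make a carboxylic acid, on that carbonyl carbon would give a readable number in this assay remains open. Also open, on these data alone, is whether 1-methyl-1H-pyrazol-4-yl would give a readable number alongside cyclopropylamino.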